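This account rests on a few compounds, and the source may have more. Where it says the series, first, only, none or still open, it means among the compounds named here.

Compound 1 `C=CCOC(=O)NS(=O)(=O)Nc1cccc(-c2cc3ccccc3[nH]2)c1` and compound 3 `CCCCCCCCOC(=O)NS(=O)(=O)Nc1cccc(-c2cc3ccccc3[nH]2)c1` share one core, while compound 2 `C=CCOC(=O)NS(=O)(=O)Nc1cc(-c2cc3cc(F)ccc3[nH]2)ccc1OC` and compound 4 `CCCCCCCCOC(=O)NS(=O)(=O)Nc1cc(-c2cc3cc(F)ccc3[nH]2)ccc1OC` share another; the difference between the two cores is not broken down here. In an assay for inhibition of Polyunsaturated fatty acid lipoxygenase ALOX15 (Oryctolagus cuniculus), read by spectrophotometry (a lower number here means a stronger inhibitor, a higher number a weaker inhibitor), compound 1 gives only a limit, > 50000 nM, and no number. Compound 3 in this assay gives 2790 nM. Compound 2 gives 23300 nM in this assay, the higher of the two numbers reported, with compound 3 as its nearest neighbour. Compound 4 has not yet been measured in this assay.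

From compound 1 to compound 3 the change is heptyl in place of vinyl on a saturated chain carbon bound to an oxygen next to a carbonyl group, and it made an at least 17-fold lower number from compound 1 to compound 3 (1.25 log units; beyond the scatter). This step is reported as a bound rather than an exact number because the limit of > 50000 nM in this assay, at which 1 of the 3 values shown sits, is where compound 1 sits, so the true step may be larger than stated. From compound 2 to compound 4 the change is heptyl in place of vinyl on a saturated chain carbon bound to an oxygen next to a carbonyl group, the same change at the same place, the second time it occurs among these compounds.

The step expected in this assay is a 19-fold lower number from compound 2 to compound 4 (1.29 log units; beyond the scatter), and this expectation rests on the measured at least 17-fold lower number from compound 1 to compound 3 (1.25 log units; beyond the scatter), which may understate the effect. Compound 4 is accordingly estimated at 1200 nM in this assay, with a range expected from 300 nM to 5000 nM.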

Compound 4, half-maximal inhibitory concentration: 1080 nM
Beside the measured number, compound 4's estimate is 1.1-fold (0.05 log units) above it; low and high end bracket the measured number.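

In this assay, the exchange of allyloxycarbonyl for octyloxycarbonyl on the core of compound 2 gave a 22-fold lower number from compound 2 to compound 4 (1.33 log units; beyond the scatter), so the change that lowered the number on the core of compound 1 lowered it on this second core too, and the step is large on both. This shows that the direction of the change carries over between these two cores, but it does not show that the step has the same size on each, and it says nothing about any third core: the same change on two cores in this assay, an at least 17-fold lower number (1.25 log units; beyond the scatter) from compound 1 to compound 3 and a 22-fold lower number (1.33 log units; beyond the scatter) from compound 2 to compound 4; the limit leaves it open whether they differ Compound 1 stands at a limit of the assay, > 50000 nM, and not at a number: the limit of > 50000 nM in this assay, at which 1 of the 4 values shown sits.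

The compounds shown hold only the allyl and octyl chains at this place, so it remains open whether a chain of intermediate length, a longer chain, a branched chain, or a chain ending in an amine or a carboxylic acid would follow the same course on either core. From the compounds shown here alone, the difference between the two cores is not broken down by these compounds, so what each part of that difference contributes to the numbers also remains open.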